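The source may report more compounds than this note shows. Statements on the series, on what has been measured and on what is new or still open speak of the compounds shown alone.

Working notes on the series. Compound 1 `O=C(Nc1ccc(F)cc1)c1cc(=O)[nH]c2cc(Br)ccc12` carries a bromo on the shared core. In a functional assay on KYSE-410 cells (Homo sapiens) for antiproliferative activity, read by MTT assay, with a stated time of 72 h (on this read-out higher numbers stand for weaker inhibition and lower numbers for stronger inhibition), compound 1 gives > 20000 nM, which is a limit of the assay and not a number. Compound 2 `O=C(Nc1ccc(C(F)(F)F)cc1)c1cc(=O)[nH]c2cc(Br)ccc12` likewise gives > 20000 nM in this assay, again a limit. The step that the two limits leave unreadable from compound 1 to compound 2 therefore cannot be read; it rests on (the limit of > 20000 nM in this assay, at which 2 of the 3 values shown sit). Within the data shown here, compound 3 `O=C(Nc1cccc(F)c1)c1cc(=O)[nH]c2cc(-c3cccc(F)c3)ccc12`, with a 3-fluorophenyl on the core in place of the bromo, is the only member of the set with a measured number, giving 10900 nM in this assay. The values of compound 1 and compound 2 are limits.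

Compound 4 `O=C(Nc1cccc(F)c1)c1cc(=O)[nH]c2cc(-c3ccc(F)c(CO)c3)ccc12` is not yet measured. It differs from compound 3 by 4-fluoro-3-(hydroxymethyl)phenyl in place of 3-fluorophenyl on an aromatic carbon. Among the measured compounds shown here, no measured step touches this position: the one step recorded, from compound 1 to compound 2, sits on the amide aryl and is unreadable in size. There is thus no basis for expecting a step beyond the scatter in this assay, and the change is expected to leave potency near that of compound 3, with a 1.1-fold lower number from compound 3 to compound 4 (0.04 log units; within the scatter) as the estimated step. Compound 4 is expected to give 10000 nM in this assay, within a range of 4000 nM to 20000 nM.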

Compound 4, half-maximal inhibitory concentration: > 20000 nM
Compound 4 ended at the assay's limit; the forecaster's own chance of this, stated with the estimate: 25%; middle value at least 2.0-fold (0.30 log units) from the limit.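

Among these compounds, the first step on this position in this assay reads an at least 1.8-fold higher number from compound 3 to compound 4 (0.26 log units; that floor lies within the scatter) with 4-fluoro-3-(hydroxymethyl)phenyl in place of 3-fluorophenyl on the aromatic carbon, so this change brings no readable gain in inhibition over the one measured number in the set. Compound 4 gives > 20000 nM as a limit of the assay and not a number. The printed floor of the step stays within the usual scatter, and the true size of the step cannot be read, because the result ends at the same limit as the bromo compounds: the limit of > 20000 nM in this assay, at which 3 of the 4 values shown sit.

The change alters two things on the aryl group at once, so the compounds shown leave open whether the hydroxymethyl or the shifted fluoro sets the result, and whether an amine, a carboxylic acid or a longer chain carrying the hydroxyl in place of the hydroxymethyl would return a number inside the range of this assay at this position. Among the compounds shown here, with compound 3 the only member of the set holding a number, no trend at this position can yet be drawn.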